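The source may hold more compounds than are shown below. What is called first, only, known or untested is meant among the compounds shown, and "the series" means these compounds.

Compound 3 `CCOc1cc(NC(=O)C2(NC(=O)c3ccc4c(C5CCCC5)c(-c5ncc(Cl)cn5)n(C)c4c3)CCC2)ccc1/C=C/C(=O)OCC(=O)OCc1ccc(Cl)cc1` was examined in an ADME assay (liver) for pharmacokinetics, with Liver microsome (Homo sapiens) as the target, using microsomes (a lower number here means that the compound disappears faster, a higher number that the compound lasts longer), where it gives 5.62 h. Among the two plain numbers in this assay, compound 3 stands highest; its closest neighbour is compound 2 `CCOc1cc(NC(=O)C2(NC(=O)c3ccc4c(C5CCCC5)c(-c5ncc(Cl)cn5)n(C)c4c3)CCC2)ccc1/C=C/C(=O)OCC(=O)OC`, which gives 2.1 h, so that a 2.7-fold higher number from compound 2 to compound 3 (0.43 log units; beyond the scatter). Compound 1 `CCOc1cc(NC(=O)C2(NC(=O)c3ccc4c(C5CCCC5)c(-c5ncc(Cl)cn5)n(C)c4c3)CCC2)ccc1/C=C/C(=O)OCCOc1ccccc1` reaches only a limit of the assay, > 5 h, as recorded in the limit of > 5 h in this assay, at which 1 of the 3 values shown sits. From that limit, an at least 2.3-fold lower number from compound 1 to compound 2 (0.37 log units; beyond the scatter), whereas a step that the limit leaves unreadable from compound 1 to compound 3.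

Compound 4 `CCOc1cc(NC(=O)C2(NC(=O)c3ccc4c(C5CCCC5)c(-c5ncc(Cl)cn5)n(C)c4c3)CCC2)ccc1/C=C/C(=O)OCC(=O)N(C)C(C)C` is the next candidate. Its change is isopropyl(methyl)amino in place of (4-chlorobenzyl)oxy on a carbonyl carbon. Among the measured compounds shown here, the step most relevant to it is the one from compound 2 to compound 3, where adding the ring-bearing group at this end of the chain gave a 2.7-fold higher number from compound 2 to compound 3 (0.43 log units; beyond the scatter); compound 4 removes that ring again while also exchanging the (4-chlorobenzyl)oxy group for isopropyl(methyl)amino, a change without a direct precedent here. A modest decrease is therefore expected, a 1.9-fold lower number from compound 3 to compound 4 (0.27 log units; within the scatter), with some uncertainty. Compound 4 is estimated at 3 h, plausibly between 1.5 h and 6 h.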

Compound 4, half-life: 0.65 h
Compound 4: middle estimate off by 4.6-fold (0.66 log units), on the high side, outside the stated range (below it).
By their numbers in this assay, from the lowest: compound 4; then compound 2; then compound 3.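

Putting isopropyl(methyl)amino on this carbonyl carbon brings an 8.6-fold lower number from compound 3 to compound 4 (0.94 log units; beyond the scatter) in this assay, and also a 3.2-fold lower number from compound 2 to compound 4 (0.51 log units; beyond the scatter). Among the compounds shown here, compound 2 carries no ring at this end either, so the absence of the ring alone does not set compound 4 apart, and the earlier compounds, all with an oxygen-linked or phenoxymethyl end, could not show this. Counted from a limit of the assay rather than a plain number, the drop also reads as an at least 7.6-fold lower number from compound 1 to compound 4 (0.88 log units; beyond the scatter).

For the compounds shown here, only one amino group appears at this carbonyl carbon, so it stays open whether dimethylamino or piperidine would give a similar number. A 4-chlorobenzylamino group would show whether the chlorinated ring restores the number when nitrogen replaces the oxygen.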